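A few compounds are considered here, and "the series" means these few. Any claim that something is new, unique, unknown or untested is made for them only; others in the source may bear on it.

In an assay on isolated protein for inhibition of protein deacetylase HDAC6 (Homo sapiens), read by fluorescence, with stated times of 10 min and 2 h (on this read-out lower numbers stand for stronger inhibition and higher numbers for weaker inhibition), compound 3 `O=C(NO)c1ccc(CN2C(=O)NC(Cc3ccc(Cl)cc3)(c3ccccc3)C2=O)cc1` gives 54 nM, the lowest of the three numbers shown, though all three lie within the scatter of one another: compound 2 `O=C(NO)c1ccc(CN2C(=O)NC(Cc3ccccc3)(c3ccccc3)C2=O)cc1` gives 71.9 nM and compound 1 `CC1(c2ccccc2)NC(=O)N(Cc2ccc(C(=O)NO)cc2)C1=O` gives 74.9 nM. The steps of a 1.0-fold lower number from compound 1 to compound 2 (0.02 log units; within the scatter) and a 1.4-fold lower number from compound 1 to compound 3 (0.14 log units; within the scatter) stayed within the scatter, as did a 1.3-fold lower number from compound 2 to compound 3 (0.12 log units; within the scatter). Compound 4 `COc1ccc(CC2(c3ccccc3)NC(=O)N(Cc3ccc(C(=O)NO)cc3)C2=O)cc1` differs from compound 3 by methoxy in place of chloro on an aromatic carbon. Within the data shown here, the one measured step that touched the same aromatic carbon, a 1.3-fold lower number from compound 2 to compound 3 (0.12 log units; within the scatter), was small, and no step has yet left the scatter. No change beyond the scatter is therefore expected for compound 4 in this assay, and the estimate for compound 4 is 55 nM (range 25 nM to 120 nM). This corresponds to an expected step of a 1.0-fold higher number from compound 3 to compound 4 (0.01 log units; within the scatter).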

Compound 4, half-maximal inhibitory concentration: 72.4 nM
For compound 4 the middle estimate is 1.3-fold (0.12 log units) below the measured one; measured number inside the range.
By their numbers in this assay, from the lowest: compounds 3, 2, 4 and 1 (each within the scatter of the next).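

Methoxy on this aromatic carbon, para to a large group, brings a hydrogen-bond acceptor to the place, yet in this assay the change reads as a 1.3-fold higher number from compound 3 to compound 4 (0.13 log units; within the scatter) against chloro and a 1.0-fold higher number from compound 2 to compound 4 (0.00 log units; within the scatter) against hydrogen. Placed on the saturated chain carbon, the whole 4-methoxyphenyl gives a 1.0-fold lower number from compound 1 to compound 4 (0.01 log units; within the scatter) and so, like phenyl and 4-chlorophenyl, does not leave the scatter. Nothing available explains this flat result. Open, as far as these compounds go, is whether an amine or a carboxylic acid on this aromatic carbon would move the number beyond the scatter. Also open, from the compounds shown here alone, is whether a longer chain in place of 4-methoxybenzyl would do so.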